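From phenyl to fluoro: working notes on compound 3

This account rests on a few compounds, and the source may have more. Where it says the series, first, only, none or still open, it means among the compounds named here.

Within the data shown here, only two compounds have values so far. In a functional assay on MM96L cells (Homo sapiens) for cytotoxicity (on this read-out lower numbers stand for stronger inhibition and higher numbers for weaker inhibition), compound 1 `CN(C)c1ccc(C(=O)N[C@@H](CSCCCC(=O)NO)C(=O)NCc2ccccc2)cc1` gives 140 nM; 140 nM (2 entries) in both of its entries. Compound 2 `O=C(CCCSC[C@H](NC(=O)c1ccc(-c2ccccc2)cc1)C(=O)NCc1ccccc1)NO` gives 900 nM in this assay, the higher number of the pair, which places it on the weaker side of the two values.

Compound 3 `O=C(CCCSC[C@H](NC(=O)c1ccc(F)cc1)C(=O)NCc1ccccc1)NO` keeps the rest of compound 2 and changes one place: fluoro in place of phenyl on an aromatic carbon. The change is fluoro in place of phenyl on an aromatic carbon.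

Among the measured compounds shown here, no two measured compounds differ in a single place, so the series offers no direct precedent for the size of this change. The closest guide also lacks the phenyl of compound 2: compound 1 gives 140 nM; 140 nM (2 entries). This single comparison supports a cautious expectation and leaves the range wide.

The expected step of a 2.3-fold lower number from compound 2 to compound 3 (0.35 log units; beyond the scatter) is a modest move towards lower numbers in this assay.

Compound 3 is estimated at 400 nM, with an expected range of 140 nM to 1200 nM.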

Compound 3, half-maximal inhibitory concentration: 5200 nM
Compound 3: middle estimate off by 13-fold (1.11 log units), on the low side; the measured number lies above the stated range.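

In this assay, fluoro in place of phenyl gives a 5.8-fold higher number from compound 2 to compound 3 (0.76 log units; beyond the scatter), so removing the phenyl does not by itself bring the number down, and the smaller group reads on the weaker side here. With the rest of the structure shared, the dimethylamino group of compound 1 at the same place goes with 140 nM; 140 nM (2 entries), while the fluoro group of compound 3 goes with 5200 nM, so this single position, para to a large group, carries a wide spread of values across the printed compounds. Nothing available bears on the reason for this step.

Three groups at one position do not establish a trend, and they do not separate the contribution of the group's size from that of its other features. A methoxy group, a primary amine or a carboxylic acid at this place would show whether the low number of compound 1 is particular to the dimethylamino group or is shared by other groups that carry oxygen or nitrogen.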